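A Chlorophenyl Group Replaces Dimethylphenyl on the Sulfur

The source may hold more compounds than are shown below. What is called first, only, known or untested is meant among the compounds shown, and "the series" means these compounds.

Among the compounds with values here, in a functional assay on A-375 cells (Homo sapiens) for inhibition, read by CCK-8 assay, with a stated time of 72 h, tested at 2 uM (on this read-out higher numbers stand for more inhibition of growth at the one concentration tested and lower numbers for less inhibition of growth), compound 1 `COc1ccc(SCc2ccc(/C=C/C(=O)Nc3ccccc3N)cc2)cc1OC` gives 46% and compound 2 `Cc1cc(C)cc(SCc2ccc(/C=C/C(=O)Nc3ccccc3N)cc2)c1` gives 8.78% as the lower of the two numbers so far. Compound 3 `Nc1ccccc1NC(=O)/C=C/c1ccc(CSc2ccc(Cl)cc2)cc1` has not yet been measured. Its difference from compound 2 is 4-chlorophenyl in place of 3,5-dimethylphenyl on a sulfur and puts 4-chlorophenyl in place of 3,5-dimethylphenyl on a sulfur. Within the data shown here, one measured step bears on this change. That step is a number 37.2 percentage points lower from compound 1 to compound 2 (beyond the scatter) and it is large, beyond the scatter, and made at the same sulfur. Among the measured compounds shown here, it shows that the group there can move the number strongly, yet no measured compound carries the 4-chlorophenyl group. A moderate rise is therefore expected, smaller than that step, with wide uncertainty. The expected step runs a number 15.2 percentage points higher from compound 2 to compound 3 (beyond the scatter) in this estimate. Compound 3 is expected at 24% within an estimated range from 8% to 48% on this measure.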

Compound 3, percent growth inhibition at one concentration: 13.4%
The estimate for compound 3 lay 10.6 percentage points above the measured number; the measured number falls inside the stated range.
By their numbers in this assay, from the lowest: compounds 2 and 3 (each within the scatter of the next); then compound 1.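

In this assay, the step of a number 4.6 percentage points higher from compound 2 to compound 3 (within the scatter) stays within the usual scatter, so 4-chlorophenyl and 3,5-dimethylphenyl on the sulfur cannot be told apart on this read-out. The step of a number 32.6 percentage points lower from compound 1 to compound 3 (beyond the scatter) is large and beyond the scatter, so a second replacement for the 3,4-dimethoxyphenyl group also gives a much lower number, and among these three groups on the sulfur, only 3,4-dimethoxyphenyl gives the higher one. No evidence at hand accounts for this gap.

From the compounds shown here alone, it remains open whether a single methoxy group, a hydroxyl or an amine on that aromatic ring would keep the number of compound 1. Also open, going by these compounds, is how a longer chain in place of the saturated chain carbon on the sulfur would read.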